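Benzyl in Place of Pyridinylmethyl on a Piperazine Thiocarbamate

The source may report more compounds than this note shows. Statements on the series, on what has been measured and on what is new or still open speak of the compounds shown alone.

The measured compounds:
compound 1 `Nc1ccccc1NC(=O)c1ccc(CSC(=S)N2CCCc3ccccc32)cc1`, 26.1%;
compound 2 `Nc1ccccc1NC(=O)c1ccc(CSC(=S)N2CCN(Cc3ccncc3)CC2)cc1`, 59.5%;
compound 3 `COC(=O)c1ccc2c(c1)CCN2C(=S)SCc1ccc(C(=O)Nc2ccccc2N)cc1`, 45.3%.

These three were tested in a functional assay on HeLa cells (Homo sapiens) for antiproliferative activity, read by CCK-8 assay, with a stated time of 72 h, tested at 2 uM; on this read-out higher numbers stand for a stronger effect at the one concentration tested and lower numbers for a weaker effect. Compound 2 gives the highest of the three numbers, 59.5%, with compound 3 next at 45.3% and compound 1 furthest at 26.1%; both gaps lie beyond the scatter.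

Compound 4 `Nc1ccccc1NC(=O)c1ccc(CSC(=S)N2CCN(Cc3ccccc3)CC2)cc1` has not been measured. It differs from compound 2 in one place: phenyl in place of pyridin-4-yl on a saturated chain carbon bound to an amine nitrogen in a ring. Among the measured compounds shown here, no measured pair shows this change, so its effect is unknown. A small step in this assay is expected, likely not beyond the scatter, perhaps slightly downward, giving a number 9.5 percentage points lower from compound 2 to compound 4 (within the scatter). Compound 4 is therefore expected at 50%, within 30% to 70%.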

Compound 4, a percentage reported as inhibition, at one concentration (the size of the read-out at that concentration, not a potency): 20.6%
Beside the measured number, compound 4's estimate is 29.4 percentage points above it; the whole stated range lies above it.
By their numbers in this assay, from the lowest: compounds 4 and 1 (each within the scatter of the next); then compound 3; then compound 2.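

In this assay, replacing pyridin-4-yl with phenyl on this saturated chain carbon gives a number 38.9 percentage points lower from compound 2 to compound 4 (beyond the scatter). The two groups have the same number of heavy atoms, and one ring nitrogen gives way to carbon, so even this single-atom change matters greatly at this position. Nothing available here accounts for the size of the step. The compounds shown leave open how pyridin-3-yl, pyridin-2-yl or pyrimidin-5-yl would compare in the same place. They also leave open whether a longer chain carrying pyridin-4-yl would give a similar result.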